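Changing the Ring Nitrogen Substituent: What to Expect

The source may report more compounds than this note shows. Statements on the series, on what has been measured and on what is new or still open speak of the compounds shown alone.

Compound 1 `C=CCN1CCN(C(=S)SCC(=O)Nc2cccc(NC(=O)c3ccccn3)c2)CC1`: 210 nM
Compound 2 `CC(C)(C)OC(=O)N1CCN(C(=S)SCC(=O)Nc2cccc(NC(=O)c3ccccn3)c2)CC1`: 180 nM

Both compounds were tested in a functional assay on A549 cells (Homo sapiens) for antiproliferative activity, read by MTT assay, with a stated time of 48 h; a higher number here means a weaker inhibitor, a lower number a stronger inhibitor. Compound 2 stands at one end of the two numbers, with compound 1 nearest, but the step of a 1.2-fold lower number from compound 1 to compound 2 (0.07 log units; within the scatter) lies within the scatter, so the two compounds are effectively indistinguishable in this assay .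

Compound 3 `O=C(CSC(=S)N1CCN(c2ncccn2)CC1)Nc1cccc(NC(=O)c2ccccn2)c1` is not yet measured. It differs from compound 2 in one place: pyrimidin-2-yl in place of tert-butoxycarbonyl on an amine nitrogen in a ring. Within the data shown here, the only measured step that bears on this position is a 1.2-fold lower number from compound 1 to compound 2 (0.07 log units; within the scatter), where a different group on the same ring nitrogen left the number essentially unchanged. On that basis, the change in compound 3 is expected to produce a step of a 1.1-fold higher number from compound 2 to compound 3 (0.05 log units; within the scatter), that is, nothing beyond the scatter. Compound 3 is therefore estimated at 200 nM in this assay , with a likely range from 80 nM to 500 nM.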

Compound 3, half-maximal inhibitory concentration: 40 nM
The estimate for compound 3 lay 5.0-fold (0.70 log units) above the measured number; the measured number lies below the stated range.
By their numbers in this assay, from the lowest: compound 3; then compounds 2 and 1 (each within the scatter of the next).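

This position is not indifferent to what it carries. In this assay, pyrimidin-2-yl in place of tert-butoxycarbonyl gives a 4.5-fold lower number from compound 2 to compound 3 (0.65 log units; beyond the scatter), and pyrimidin-2-yl in place of allyl gives a 5.3-fold lower number from compound 1 to compound 3 (0.72 log units; beyond the scatter), although the two earlier groups could not be told apart. Of these three groups, only pyrimidin-2-yl brings an aromatic ring to the ring nitrogen, but nothing available here explains why this change lowers the number.

These compounds leave open whether any aromatic ring on this nitrogen would do the same, or whether the two ring nitrogens of pyrimidin-2-yl are needed, a question that phenyl or pyridin-2-yl could answer. They also leave open how a small group, such as methyl, or a bare hydrogen on this nitrogen would compare.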